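The compounds below may be only part of what the source reports. "The series", "measured", "known", "first", "only" and "open" are said of these compounds alone.

Compound 1 `Cc1ccccc1N/N=C1\CCC(C)n2c1ncc(C(=O)O)c2=O` gives in a functional assay on the whole organism for inhibition, with Rattus norvegicus as the target (on this read-out higher numbers stand for an effect only at larger amounts of compound and lower numbers for an effect already at smaller amounts), a value of > 100 umol/kg, which is a limit of the assay and not a number.
Compound 2 `CC1CC/C(=N\Nc2ccccc2C(F)(F)F)c2ncc(C(=O)O)c(=O)n21` gives in this assay a value of > 1000 umol/kg, again a limit rather than a number.

Going by the values given here, compound 2 therefore stands only at a limit of this assay, and the one further value known here is also a limit. Among the compounds with values here, the single measured step, a step that the two limits leave unreadable from compound 1 to compound 2, cannot be read in size, as both ends sit at limits (the limit of > 100 umol/kg in this assay, at which 1 of the 2 values shown sits, and (the limit of > 1000 umol/kg in this assay, at which 1 of the 2 values shown sits)).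

Compound 3 `CC1CC/C(=N\Nc2ccccc2[N+](=O)[O-])c2ncc(C(=O)O)c(=O)n21` differs from compound 2 in one place: nitro in place of trifluoromethyl on an aromatic carbon. Within the data shown here, no measured step bears on this change, and the step that exists offers no readable size, so the only guidance is that both measured compounds lie at limits. The step of a number no higher from compound 2 to compound 3 (the limit leaves the size open) is thus expected to show no effect beyond the scatter. Compound 3 is estimated at 1000 umol/kg in this assay, within a range from 300 umol/kg to 3000 umol/kg, most likely reported again as a limit.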

Compound 3, dose for 50% inhibition: > 1000 umol/kg
Compound 3: a limit, no number; the forecaster's own chance of this, stated with the estimate: 80%; the middle value lies on the limit itself.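

None of the steps among compound 1, compound 2 and compound 3 can be read in size; all three values in this assay are limits of the assay, not numbers. The compounds shown leave open whether methyl, trifluoromethyl or nitro on the aromatic carbon changes the dose needed for inhibition.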